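Removing one methyl from compound 1

The source may report more compounds than this note shows. Statements on the series, on what has been measured and on what is new or still open speak of the compounds shown alone.

Measured so far in an ADME assay on MT4 cells (Homo sapiens) for cytotoxicity, read by MTT assay, with a stated time of 96 h (on this read-out higher numbers stand for lower toxicity in this test and lower numbers for higher toxicity in this test), are these compounds:
compound 1 (`Cc1ccccc1C1CC(c2ccc(OCc3ccccc3)cc2)=NN1c1ccc(S(N)(=O)=O)cc1`) gives >= 100000 nM (a limit of the assay, not a number)
compound 2 (`Cc1ccc(C2CC(c3ccccc3)=NN2c2ccc(S(N)(=O)=O)cc2)cc1`) gives 40000 nM (a number)
compound 3 (`NS(=O)(=O)c1ccc(N2N=C(c3ccccc3)CC2c2ccccc2Cl)cc1`) gives 44000 nM (a number)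

Compound 1 has only a limit and no number, and its standing is the limit of >= 100000 nM in this assay, at which 1 of the 3 values shown sits, and nothing more exact. Compound 4 (`NS(=O)(=O)c1ccc(N2N=C(c3ccc(OCc4ccccc4)cc3)CC2c2ccccc2)cc1`) has not yet been measured. Its structure departs from compound 1 by hydrogen in place of methyl on an aromatic carbon (hydrogen in place of methyl on an aromatic carbon, or 2-methylphenyl to phenyl).

Among the compounds with values here, one measured step bears on this change, and only loosely. A swap of groups on a saturated ring carbon gave a 1.1-fold higher number from compound 2 to compound 3 (0.04 log units; within the scatter) and so showed no change that can be told from the scatter. Compound 2 and compound 3 also differ from compound 1 elsewhere in their structures, so this step is indirect evidence. In this assay the change is therefore expected to produce no step beyond the scatter, although the limit of compound 1 leaves the starting point open. The estimated move is an at least 1.2-fold lower number from compound 1 to compound 4 (0.09 log units; that floor lies within the scatter) and is expected to stay small. For compound 4 the estimate is 80000 nM as the expected middle, with the expected range running from 35000 nM to 180000 nM in this estimate.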

Compound 4, half-maximal cytotoxic concentration: > 100000 nM
Compound 4: no number, only a limit; the forecaster's own chance of this, stated with the estimate: 45%; middle value at least 1.2-fold (0.09 log units) from the limit.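

In this assay compound 4 gives a limit, not a number: the limit of > 100000 nM in this assay, at which 1 of the 4 values shown sits.

Compound 1 also gives a limit, not a number: the limit of >= 100000 nM in this assay, at which 1 of the 4 values shown sits.

The step from compound 1 to compound 4 therefore cannot be read. The compounds shown leave open whether hydrogen in place of methyl on an aromatic carbon changes this read-out at all, and in which direction.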